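The source may report more compounds than this note shows. Statements on the series, on what has been measured and on what is new or still open speak of the compounds shown alone.

Working notes on the series. Of the compounds shown here, three with a shared core have been measured in an assay on CHO cells with Alpha-2C adrenergic receptor (Homo sapiens) as the target; a lower number here means a smaller maximal response, a higher number a larger maximal response. Compound 1 `CC(C)Oc1ccccc1OC(C)C1=NCCN1` gives 0.7 in this assay. Compound 2 `C=CCc1cccc(CC=C)c1OC(C)C1=NCCN1` gives 0.9 in this assay. Compound 3 `CC(=O)c1ccccc1OC(C)C1=NCCN1` gives 0.65 in this assay.

Compound 3 sits with compound 1 inside the scatter: the step a number 0.050 lower from compound 1 to compound 3 (within the scatter) is within it, so the two cannot be told apart. Compound 2 stands apart from compound 3 by a gap beyond the scatter, and that gap involves two changes at once, so it gives no single-change guide.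

Compound 4 `CCc1ccccc1OC(C)C1=NCCN1` has not been measured in this assay. Its difference from compound 3 is ethyl in place of acetyl on an aromatic carbon. For the measured compounds named here, the only measured single-change step, acetyl in place of isopropoxy on an aromatic carbon, was a number 0.050 lower from compound 1 to compound 3 (within the scatter), within the scatter; no measured step puts ethyl in place of acetyl, so the change in compound 4 has no direct precedent. On what is in hand, a step from compound 3 beyond the scatter in either direction is not expected in this assay.

Compound 4 is therefore estimated at 0.7 in this assay, with a range from 0.55 to 0.85. The step this estimate implies, a number 0.050 higher from compound 3 to compound 4 (within the scatter), is expected to remain within the scatter.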

Compound 4, intrinsic activity: the largest response reached, as a fraction of the reference agonist's: 0.6
Estimate against measurement, compound 4: 0.10 above; the range from low to high includes it.
By their numbers in this assay, from the lowest: compounds 4, 3 and 1 (each within the scatter of the next); then compound 2.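

On an aromatic carbon of a six-membered aromatic ring of carbon only, ortho to a group of 8 heavy atoms, acetyl with its hydrogen-bond acceptor and its double bond outside aromatic rings gives way to ethyl, which has neither, and in this assay the result is a number 0.050 lower from compound 3 to compound 4 (within the scatter), so neither that acceptor nor that double bond is needed here to keep the maximal response within the scatter. The replacement of isopropoxy by ethyl at the same place, a number 0.10 lower from compound 1 to compound 4 (within the scatter), likewise cannot be told apart from no change, which means that isopropoxy, acetyl and ethyl now form a set of three groups at this position with no separation between any measured pair in this assay. Nothing on hand offers an explanation for this flat picture.

What the compounds shown leave open is whether any group at this position can move the maximal response beyond the scatter, since all three groups seen so far are small and uncharged. An amine, a carboxylic acid or a longer chain such as butyl on the same aromatic carbon would test whether this tolerance extends to a different kind of group.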